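The source may report more compounds than this note shows. Statements on the series, on what has been measured and on what is new or still open speak of the compounds shown alone.

Compound 3 `Cc1ccc(S/C(=C/c2ccc(C)s2)C(=O)c2ccc(Br)cc2)cc1` gives > 100000 nM in a functional assay on DU-145 cells (Homo sapiens) for inhibition, read by trypan blue exclusion, with a stated time of 96 h (on this read-out lower numbers stand for stronger inhibition of growth and higher numbers for weaker inhibition of growth), which is a limit of the assay and not a number. That places compound 3 at the limit of > 100000 nM in this assay, at which 1 of the 3 values shown sits. In this assay compound 1 `Cc1ccc(S/C(=C/c2sccc2C)C(=O)c2ccc(Br)cc2)cc1` gives 50000 nM and compound 2 `Cc1ccc(S/C(=C/c2ccc(Cl)c(Cl)c2)C(=O)c2ccc(Br)cc2)cc1` gives 50000 nM.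

Compound 4 `Cc1ccc(S/C(=C/c2ccc(N(C)C)cc2)C(=O)c2ccc(Br)cc2)cc1` carries 4-(dimethylamino)phenyl in place of 5-methylthiophen-2-yl on a double-bonded chain carbon bound to a double-bonded chain carbon.

All three measured steps change this same place. They are no change at the digits printed from compound 1 to compound 2 (within the scatter), an at least 2.0-fold higher number from compound 1 to compound 3 (0.30 log units; that floor lies within the scatter) and an at least 2.0-fold higher number from compound 2 to compound 3 (0.30 log units; that floor lies within the scatter). From the compounds shown here alone, the last two are only floors, set by the limit of compound 3, so the size of any real gap remains unknown. The series therefore offers little guidance on the size of the next step. Among the measured compounds shown here, the nearest precedent is compound 2 at 50000 nM, the one measured member that also has a six-membered aromatic ring of carbon only at this place. On that basis, a reading in the same region is expected, with a return to the limit still quite possible. The expected change is an at least 2.0-fold lower number from compound 3 to compound 4 (0.30 log units; that floor lies within the scatter), a modest move to a lower number. For compound 4 the estimated value is 50000 nM, with an expected range from 15000 nM to 100000 nM.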

Compound 4, concentration for 50% growth inhibition: > 100000 nM
Compound 4: a limit, no number; the forecaster's own chance of this, stated with the estimate: 35%; at least 2.0-fold (0.30 log units) between middle value and limit.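

In this assay compound 4 gives > 100000 nM, which is a limit of the assay and not a number. Against the two compounds with a number, the change reads as an at least 2.0-fold higher number from compound 2 to compound 4 (0.30 log units; that floor lies within the scatter) and as an at least 2.0-fold higher number from compound 1 to compound 4 (0.30 log units; that floor lies within the scatter), so neither step is shown to lie beyond the scatter. A six-membered aromatic ring of carbon only at this place therefore does not by itself give a numerical reading, as compound 2 and compound 4 share that ring type and only compound 2 gives a number, and a second group now sits at the limit: the limit of > 100000 nM in this assay, at which 2 of the 4 values shown sit.

From the compounds shown here alone, the step between compound 3 and compound 4 cannot be read, as both values are limits, so the order of these two compounds and the true size of the gaps to compound 1 and compound 2 stay unknown. Also open, going by these compounds, is whether the reading at this place follows the dimethylamino group itself or the ring that carries it, which a 4-aminophenyl, a 4-methoxyphenyl or a 4-carboxyphenyl group on the double-bonded chain carbon would help to separate in this assay.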